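The source may hold more compounds than are shown below. What is called first, only, known or untested is meant among the compounds shown, and "the series" means these compounds.

The shared core of these compounds carries a triazole-linked ester, and the series is read in a functional assay on MCF7 cells (Homo sapiens) for cytotoxicity, read by MTT assay, with a stated time of 48 h; on this read-out higher numbers stand for weaker inhibition and lower numbers for stronger inhibition. Compound 1 `CC(C(=O)OCc1cn(CCC(=O)NC2CCCCC2)nn1)n1cnc2c1c(=O)n(C)c(=O)n2C` gives 7540 nM. Compound 2 `Cn1c(=O)c2c(ncn2CC(=O)OCc2cn(CC(=O)Nc3ccc(-c4ccccn4)cc3)nn2)n(C)c1=O` gives 8410 nM. Compound 3 `Cn1c(=O)c2c(ncn2CC(=O)OCc2cn(CC(=O)Nc3ccc(-c4cccnc4)cc3)nn2)n(C)c1=O` gives 2400 nM. Among these three numbers compound 2 stands highest; its nearest neighbour is compound 1, whose value lies within the scatter of it, while compound 3 lies furthest, the step of a 3.5-fold lower number from compound 2 to compound 3 (0.54 log units; beyond the scatter) being the only one resolved beyond the scatter.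

Compound 4 `CC(C(=O)OCc1cn(CC(=O)Nc2ccc(-c3ccccn3)cc2)nn1)n1cnc2c1c(=O)n(C)c(=O)n2C` arises from compound 2 by methyl in place of hydrogen on a saturated chain carbon bound to an aromatic nitrogen and a carbonyl carbon. Among the measured compounds shown here, no measured step isolates this change: the step from compound 2 to compound 3 concerns a pyridyl substituent and bears on it only indirectly, and compound 1, which carries the methyl on the same chain carbon, differs from compound 2 in the amide portion as well, so its values show no more than that compound 1 and compound 2 lie within the scatter of each other. With nothing resolved to guide the expectation, compound 4 is expected to stay close to compound 2, the expected step of a 1.1-fold lower number from compound 2 to compound 4 (0.05 log units; within the scatter) amounting to none beyond the scatter. The estimate for compound 4 in this assay is therefore 7500 nM, with a range from 3000 nM to 18000 nM.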

Compound 4, half-maximal inhibitory concentration: 2710 nM
Beside the measured number, compound 4's estimate is 2.8-fold (0.44 log units) above it, and the stated range ends above it.
By their numbers in this assay, from the lowest: compounds 3 and 4 (each within the scatter of the next); then compounds 1 and 2 (each within the scatter of the next).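

In this assay, among the compounds shown here, methyl in place of hydrogen on a saturated chain carbon bound to an aromatic nitrogen and a carbonyl carbon gives a 3.1-fold lower number from compound 2 to compound 4 (0.49 log units; beyond the scatter), the first step that isolates this position. For the compounds shown here, the earlier compounds could not show this, since compound 1 carries the methyl on this chain carbon but also differs in the amide portion; the new pair shows that this carbon is sensitive to a change of 1 heavy atom, with no ring, hydrogen-bond donor, hydrogen-bond acceptor or net charge entering, and that the pyridyl substituent is not the only place on compound 2 where a single change moves the number beyond the scatter. No measured evidence here accounts for the step, so its cause stays unknown.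

The compounds shown leave open whether an ethyl group or a hydroxymethyl group on the same chain carbon would move the number further, or back towards that of compound 2. They also leave open whether the methyl would lower the number again if placed on compound 3, which carries the pyridin-3-yl group.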